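Chain lengthening on the amide of compound 2

This account rests on a few compounds, and the source may have more. Where it says the series, first, only, none or still open, it means among the compounds named here.

Measured compounds in a functional assay on A-431 cells (Homo sapiens) for cytotoxicity, read by MTT assay, with a stated time of 48 h; on this read-out higher numbers stand for weaker inhibition and lower numbers for stronger inhibition:
Compound 1 `CCCCCCCCCCCCNC(=O)[C@@H](NC(=O)c1ccccc1)[C@@H](C)O` gives 41200 nM.
Compound 2 `CCCCCCCCCCCCNC(=O)[C@@H](NC(=O)/C=C/c1ccccc1)[C@@H](C)O` gives > 200000 nM, which is a limit of the assay, not a number.
Compound 3 `C/C=C/C=C/C(=O)N[C@H](C(=O)NCCCCCCCCCCCC)[C@@H](C)O` gives 171000 nM.

Compound 1 carries the lowest number of the three. The change an at least 4.8-fold higher number from compound 1 to compound 2 (0.68 log units; beyond the scatter) and the change a 4.2-fold higher number from compound 1 to compound 3 (0.62 log units; beyond the scatter) both lie beyond the scatter, whereas an at least 1.1-fold lower number from compound 2 to compound 3 (0.06 log units; that floor lies within the scatter) lies within it, so compound 2 and compound 3 cannot be ordered against each other. Compound 2 stands only as a limit, as shown by the limit of > 200000 nM in this assay, at which 1 of the 3 values shown sits.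

Compound 4 `CCCCCCCCCCCCCCCCCCNC(=O)[C@@H](NC(=O)/C=C/c1ccccc1)[C@@H](C)O` is the compound to be measured. It differs from compound 2 by hexyl in place of hydrogen on a saturated chain carbon, ten or more bonds along the chain from an amide-type nitrogen. Every measured step in this set changes the group on the carbonyl carbon or the double-bonded chain carbon; none varies the saturated chain on the amide nitrogen. Among the compounds with values here, no measured step therefore bears on this change, and no step beyond the scatter in this assay in either direction is expected from it. Compound 4 is expected to remain at the limit of the assay rather than give a number. The expected step is a step that the limit leaves unreadable from compound 2 to compound 4. For compound 4 the estimated value is 250000 nM, with a range from 100000 nM to 700000 nM.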

Compound 4, half-maximal inhibitory concentration: 177000 nM
Compound 4: middle estimate off by 1.4-fold (0.15 log units), on the high side, and the stated range covers the measured number.
By their numbers in this assay, from the lowest: compound 1; then compounds 3 and 4 (each within the scatter of the next). At a limit, above all of these: compound 2.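

In this assay, within the data shown here, hexyl in place of hydrogen on a saturated chain carbon, ten or more bonds along the chain from an amide-type nitrogen, is the only change in this set made on the saturated chain. With this change, compound 4 gives 177000 nM. This takes the series from a limit to a number. The printed step is an at least 1.1-fold lower number from compound 2 to compound 4 (0.05 log units; that floor lies within the scatter), so this position does tolerate the longer chain without loss of a readable value, but a real gain in strength is not established. The true size of the change remains unknown because compound 2 stands at a limit, not at a number: the limit of > 200000 nM in this assay, at which 1 of the 4 values shown sits.

The compounds shown leave open whether the same hexyl change would shift the number when phenyl or penta-1,3-dien-1-yl stands on the carbonyl carbon, as in compound 1 and compound 3. They also leave open how this position would respond to an amine or a carboxylic acid carried on the saturated chain, or to a chain longer than that of compound 4.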